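Methoxy addition on the pyridin-4-yl member of the series

The source may report more compounds than this note shows. Statements on the series, on what has been measured and on what is new or still open speak of the compounds shown alone.

Within the data shown here, in a functional assay on SMMC-7721 cells (Homo sapiens) for cytotoxicity, read by MTT assay, with a stated time of 24 h (on this read-out lower numbers stand for stronger inhibition and higher numbers for weaker inhibition), compound 3 (`COc1cc(/C=C2\CN(C)C/C(=C\c3ccncc3)C2=O)cc(OC)c1`) gives 5810 nM and stands lowest of the three numbers so far. Compound 1 (`COc1cc(/C=C2\CN(C)C/C(=C\c3cccnc3)C2=O)cc(OC)c1`) gives 17900 nM and compound 2 (`COc1cc(/C=C2\CN(C)C/C(=C\c3cccnc3)C2=O)cc(OC)c1OC`) gives 20400 nM on the same read-out.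

Compound 4 (`COc1cc(/C=C2\CN(C)C/C(=C\c3ccncc3)C2=O)cc(OC)c1OC`) differs from compound 3 by one change (methoxy in place of hydrogen on an aromatic carbon): methoxy in place of hydrogen on an aromatic carbon, ortho to two methoxy groups and para to a large group.

The same replacement has one measured precedent, in the pyridin-3-yl pair: a 1.1-fold higher number from compound 1 to compound 2 (0.06 log units; within the scatter) in that case. The other measured step (a 3.1-fold lower number from compound 1 to compound 3 (0.49 log units; beyond the scatter)) swaps pyridin-3-yl for pyridin-4-yl. It sets the level from which the new step starts and does not give its size. From the compounds shown here alone, whether the precedent carries over to the pyridin-4-yl side is untested, so the range stays wide.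

No step beyond the scatter is expected, and the expected step is a 1.1-fold higher number from compound 3 to compound 4 (0.04 log units; within the scatter) on this evidence. Compound 4 is estimated at 6400 nM (range 3200 nM to 13000 nM).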

Compound 4, half-maximal inhibitory concentration: 9130 nM
The estimate for compound 4 lay 1.4-fold (0.15 log units) below the measured number, and the stated range covers the measured number.
By their numbers in this assay, from the lowest: compounds 3, 4, 1 and 2 (each within the scatter of the next, the first and the last beyond it).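

In this assay, adding the methoxy ortho to two methoxy groups and para to a large group now has a second reading, a 1.6-fold higher number from compound 3 to compound 4 (0.20 log units; within the scatter), so it stays within the scatter on both the pyridin-3-yl and pyridin-4-yl sides: the same change on two cores in this assay, a 1.1-fold higher number (0.06 log units; within the scatter) from compound 1 to compound 2 and a 1.6-fold higher number (0.20 log units; within the scatter) from compound 3 to compound 4, 1.4-fold (0.14 log units) apart, within the scatter of two such steps. The replacement of pyridin-3-yl by pyridin-4-yl also carries over to the core bearing the added methoxy, with a 2.2-fold lower number from compound 2 to compound 4 (0.35 log units; beyond the scatter): the same change on two cores in this assay, a 3.1-fold lower number (0.49 log units; beyond the scatter) from compound 1 to compound 3 and a 2.2-fold lower number (0.35 log units; beyond the scatter) from compound 2 to compound 4, 1.4-fold (0.14 log units) apart, within the scatter of two such steps. Across these four compounds the two changes therefore read as independent of each other, and none of the four goes against this.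

Open, from the compounds shown here alone, is whether this aromatic carbon accepts groups other than hydrogen and methoxy, such as a hydroxyl, an amine or a longer ethoxy chain. Also open, going by these compounds, is whether the independence of the two changes holds for such groups.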